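The source may report more compounds than this note shows. Statements on the series, on what has been measured and on what is new or still open speak of the compounds shown alone.

In a functional assay on P388 cells (Mus musculus) for antiproliferative activity, read by colorimetric assay and MTT assay (a lower number here means a stronger inhibitor, a higher number a weaker inhibitor), compound 3 (`O=[N+]([O-])c1ccc(S(=O)(=O)Nc2cccc3cc(Cl)[nH]c23)cc1`) gives 21 ug/mL, the highest number of the three measured. Compound 2 (`O=[N+]([O-])c1ccc(S(=O)(=O)Nc2cccc3cc[nH]c23)cc1`) gives 8.2 ug/mL, and compound 1 (`COc1ccc(S(=O)(=O)Nc2cccc3cc(O)[nH]c23)cc1`) gives 0.11 ug/mL. Compound 4 (`O=[N+]([O-])c1ccc(S(=O)(=O)Nc2cccc3cc(O)[nH]c23)cc1`) has hydroxy in place of chloro on an aromatic carbon, next to the ring nitrogen: hydroxy in place of chloro on an aromatic carbon. Within the data shown here, the only measured step at this place, a 2.6-fold higher number from compound 2 to compound 3 (0.41 log units; beyond the scatter), is modest and does not involve hydroxy. Compound 1 carries hydroxy there and reads 0.11 ug/mL, but it also differs in a second place, so it gives direction more than size. A clear move to a lower number is expected, larger than the chloro step. The estimated change is an 8.4-fold lower number from compound 3 to compound 4 (0.92 log units; beyond the scatter). For compound 4 the estimate is 2.5 ug/mL, with an expected range of 0.4 ug/mL to 12 ug/mL.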

Compound 4, half-maximal inhibitory concentration: > 100 ug/mL
Compound 4: no number, only a limit; the forecaster's own chance of this, stated with the estimate: 3%; at least 40-fold (1.60 log units) between middle value and limit.
By their numbers in this assay, from the lowest: compound 1; then compound 2; then compound 3. At a limit, above all of these: compound 4.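

In this assay compound 4 gives a limit, not a number: the limit of > 100 ug/mL in this assay, at which 1 of the 4 values shown sits. With nitro held, hydroxy on this aromatic carbon next to the ring nitrogen gives an at least 4.7-fold higher number from compound 3 to compound 4 (0.67 log units; beyond the scatter) in place of chloro, and an at least 12-fold higher number from compound 2 to compound 4 (1.08 log units; beyond the scatter) in place of hydrogen, so hydroxy here does not by itself lower the number. With hydroxy held, nitro in place of methoxy gives an at least 900-fold higher number from compound 1 to compound 4 (2.95 log units; beyond the scatter), so the low number of compound 1 does not follow from hydroxy alone.

Open: how methoxy reads with hydrogen or chloro at this carbon, and how an amine or a methyl group reads there.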